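The source may hold more compounds than are shown below. What is called first, only, known or untested is meant among the compounds shown, and "the series" means these compounds.

Measured so far:
compound 1 `COc1ccc(-c2cc3c(s2)C2(CCN(Cc4ccccc4)CC2)OC(OC)C3)cc1` — 56 nM
compound 2 `COC1Cc2cc(-c3ccc([N+](=O)[O-])cc3)sc2C2(CCN(Cc3ccccc3)CC2)O1` — 16 nM
compound 3 `c1ccc(CN2CCC3(CC2)OCCc2ccsc23)cc1` — 1 nM

In an assay on membranes from brain for displacement of a labelled ligand from Sigma non-opioid intracellular receptor 1 (Cavia porcellus), read by scintillation counting, with a stated time of 120 min (on this read-out higher numbers stand for weaker inhibition and lower numbers for stronger inhibition), compound 3 gives the lowest number of the three measured compounds: compound 2 stands a large way above it, and compound 1 further still. Compound 4 `COC1Cc2ccsc2C2(CCN(Cc3ccccc3)CC2)O1` differs from compound 3 in one place: methoxy in place of hydrogen on a saturated ring carbon, on a saturated ring carbon of a six-membered non-aromatic ring with 1 oxygen, within the fused system of three rings.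

Among the measured compounds shown here, the one step measured so far, a 3.5-fold lower number from compound 1 to compound 2 (0.54 log units; beyond the scatter), changes a group on an aromatic carbon of a separate ring and therefore says nothing direct about the methoxy on the saturated ring carbon. Compounds 1 and 2 both carry that methoxy together with an aryl group that compound 3 lacks, so their higher numbers cannot be assigned to either change alone. For the measured compounds named here, with no step isolating this change, the expectation for compound 4 rests only on this weak indication, and the step of a 3.0-fold higher number from compound 3 to compound 4 (0.48 log units; beyond the scatter) is expected to be small and upward, though a result within the scatter would not surprise. Compound 4 is accordingly estimated at 3 nM, with a range from 1 nM to 12 nM.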

Compound 4, inhibition constant: 1.9 nM
Estimate against measurement, compound 4: 1.6-fold (0.20 log units) above; the measured number falls inside the stated range.
By their numbers in this assay, from the lowest: compounds 3 and 4 (each within the scatter of the next); then compound 2; then compound 1.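

In this assay, methoxy in place of hydrogen on the saturated ring carbon next to the ring oxygen gives a 1.9-fold higher number from compound 3 to compound 4 (0.28 log units; within the scatter), so on this core the change cannot be told from repeat variation, and this position accepts the methoxy without a measurable penalty. That separates the two changes that compounds 1 and 2 had left tangled: with the methoxy present in all three compounds, hydrogen in place of 4-methoxyphenyl on the aromatic carbon gives a 29-fold lower number from compound 1 to compound 4 (1.47 log units; beyond the scatter), and hydrogen in place of 4-nitrophenyl gives an 8.4-fold lower number from compound 2 to compound 4 (0.93 log units; beyond the scatter), so the higher numbers of compounds 1 and 2 go with the aryl groups and not with the methoxy. Why the aryl groups carry this cost remains unexplained, as no supporting measurement bears on it.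

The compounds shown hold only hydrogen or methoxy on the saturated ring carbon, leaving open what a hydroxyl, an ethoxy or an amine would do there. Also open, from the compounds shown here alone, is whether a small group such as methyl or chlorine on the aromatic carbon would stay close to compound 4 or move towards compounds 1 and 2.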